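Cyclopropyl for cyclohexyl on an alkyne: expected tolerance

The compounds below may be only part of what the source reports. "The series", "measured", "known", "first", "only" and "open" are said of these compounds alone.

Measured compounds and their values:
compound 1 `C[Si](C)(C)C#Cc1c[nH]c(=O)[nH]c1=O`: 270000 nM
compound 2 `O=c1[nH]c(=O)n([C@@H]2O[C@H](CO)[C@@H](O)[C@H]2O)cc1C#CC1CCCCC1`: 148000 nM
compound 3 `O=c1[nH]cc(C#CC2CC2)c(=O)[nH]1`: 252000 nM

All three were tested in an ADME assay on Vero cells (Chlorocebus sabaeus) for cytotoxicity, read by MTT assay; a higher number here means that more compound is tolerated, a lower number that less compound is tolerated. Compound 2 gives 148000 nM; compound 3 sits nearest with 252000 nM, and compound 1 furthest with 270000 nM, yet both gaps stay within the scatter, so the three numbers cannot be told apart.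

Compound 4 `O=c1[nH]c(=O)n([C@@H]2O[C@H](CO)[C@@H](O)[C@H]2O)cc1C#CC1CC1` has not been measured. It differs from compound 2 by cyclopropyl in place of cyclohexyl on a triple-bonded carbon.

Going by the values given here, one measured step touches the same place: a 1.1-fold lower number from compound 1 to compound 3 (0.03 log units; within the scatter), where a cyclopropyl also enters on a triple-bonded carbon. Among the compounds with values here, that step stayed within the scatter, and no measured pair separates cyclohexyl from cyclopropyl directly, so the shape of the group at that position has left this assay unmoved so far. The expectation is therefore no step beyond the scatter, expressed as a 1.4-fold higher number from compound 2 to compound 4 (0.13 log units; within the scatter).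

Compound 4 is estimated at 200000 nM, expected between 100000 nM and 400000 nM.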

Compound 4, half-maximal cytotoxic concentration: 133000 nM
Beside the measured number, compound 4's estimate is 1.5-fold (0.18 log units) above it; measured number inside the range.
By their numbers in this assay, from the lowest: compounds 4, 2, 3 and 1 (each within the scatter of the next, the first and the last beyond it).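

In this assay, cyclopropyl in place of cyclohexyl gives a 1.1-fold lower number from compound 2 to compound 4 (0.05 log units; within the scatter), so the two rings are now compared directly, with the rest of the molecule unchanged. On a triple-bonded carbon, the six-membered carbon ring can therefore give way to the three-membered one without the number moving beyond the scatter, and this holds on the core of compound 2, not only on the core of compound 1. Nothing measured here offers a reason for this flat result.

What happens with an amine, a carboxylic acid or a longer straight chain at this position remains open, since every group shown at this position is free of hydrogen-bond donors and acceptors. Whether this swap would also leave a different kind of measurement unmoved cannot be told from this assay alone.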